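Bromo in Place of Hydrogen on Two Related Cores

The compounds below may be only part of what the source reports. "The series", "measured", "known", "first", "only" and "open" are said of these compounds alone.

Compound 1 `Cc1nc2ccccc2c(=O)n1NCC(=O)NNC(N)=S` and compound 3 `Cc1nc2ccc(Br)cc2c(=O)n1NCC(=O)NNC(N)=S` share one core; compound 2 `COc1ccc(C2SCC(=O)N2c2nnc(CNn3c(C)nc4ccccc4c3=O)s2)cc1` and the yet unmeasured compound 4 `COc1ccc(C2SCC(=O)N2c2nnc(CNn3c(C)nc4ccc(Br)cc4c3=O)s2)cc1` share another. How the two cores differ is not broken down here. In a functional assay on the whole organism (strain albino) with Rattus norvegicus as the target, in the maximal electroshock model, with a stated time of 1 h, at a dose of 30 mg/kg by the intraperitoneal route (a higher number here means more inhibition at the dose given (going by the name of the read-out), a lower number less inhibition), compound 1 gives 30%. Compound 3 carries the change (bromo in place of hydrogen on an aromatic carbon), and in this assay compound 3 gives 30%; the step of no change at the digits printed from compound 1 to compound 3 (within the scatter) is the result. Compound 2 gives 60% in this assay, the highest of the three measured numbers, beyond the scatter from both compound 1 and compound 3.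

Compound 4 differs from compound 2 by bromo in place of hydrogen on an aromatic carbon, the same change as from compound 1 to compound 3, with the same place described around it. Because the step of no change at the digits printed from compound 1 to compound 3 (within the scatter) stayed within the scatter, the step of no change at the digits printed from compound 2 to compound 4 (within the scatter) is expected to be small as well. Compound 4 is therefore estimated to give about 60% in this assay, with a range from 40% to 80%.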

Compound 4, a percentage reported as inhibition, in the whole organism at one dose (the size of the read-out at that dose, not a potency): 60%
Estimate against measurement, compound 4: no gap at the digits printed, within the range that was stated.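

In this assay, the result of bromo in place of hydrogen on an aromatic carbon of the second core is no change at the digits printed from compound 2 to compound 4 (within the scatter). Set beside the earlier step on the first core, the two results agree: the same change on two cores in this assay, no change at the digits printed (within the scatter) from compound 1 to compound 3 and no change at the digits printed (within the scatter) from compound 2 to compound 4, 0 percentage points apart, within the scatter of two such steps

For these two pairs, then, the change carried over from one core to the other, and in neither pair did it move the inhibition measured at the single dose. This does not show that bromo would behave the same way on a third core, and a reading at one dose says nothing about potency, so a difference at other doses remains possible.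

The compounds shown leave open whether a different group at this place, such as chloro, methoxy or an amine, would also leave the inhibition where it is. They also leave open what bromo would do on another carbon of the same aromatic ring.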